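One More Methoxy on a Compound at the Limit

A few compounds are considered here, and "the series" means these few. Any claim that something is new, unique, unknown or untested is made for them only; others in the source may bear on it.

Compound 1 (`COc1ccc(C23OCC24C(CO)C4Cc2cc(OC)c(OC)cc23)cc1OC`) gives > 100000 nM in a functional assay on DU-145 cells (Homo sapiens) for cytotoxicity (on this read-out lower numbers stand for stronger inhibition of growth and higher numbers for weaker inhibition of growth), and that value is a limit of the assay, not a number. Compound 2 (`COc1ccc(C23OCC24C2COC(c5cc(OC)c(OC)cc53)C24)cc1OC`) gives > 100000 nM in this assay and that too is only a limit. Among the measured compounds shown here, compound 2 therefore stands at the same limit as compound 1 (the limit of > 100000 nM in this assay, at which 2 of the 2 values shown sit) and no measured step exists to guide a forecast. Compound 3 (`COc1cc2c(cc1OC)C1(c3cc(OC)c(OC)c(OC)c3)OCC13C1COC2C13`) differs from compound 2 in one place (methoxy in place of hydrogen on an aromatic carbon), with methoxy in place of hydrogen on an aromatic carbon, ortho to a methoxy group. No step beyond the usual scatter is expected in either direction in this assay (a number no higher from compound 2 to compound 3 (the limit leaves the size open)), and another limit is the likeliest report. Compound 3 is estimated at 100000 nM as its expected value (expected range 30000 nM to 200000 nM).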

Compound 3, concentration for 50% growth inhibition: 29500 nM
Compound 3: the middle estimate sits 3.4-fold (0.53 log units) above what was measured; the whole stated range lies above it.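

In this assay, methoxy in place of hydrogen on an aromatic carbon, ortho to a methoxy group, gives an at least 3.3-fold lower number from compound 2 to compound 3 (0.53 log units; beyond the scatter). This shows that a change at this position of the aryl ring can move the read-out, something compounds 1 and 2 could not show, as neither gives a value that is a number. The true size of the step remains unknown because the starting point is only a limit: the limit of > 100000 nM in this assay, at which 2 of the 3 values shown sit.

This is a single step on a single core, so it leaves open whether the same change would lower the number on the core of compound 1. From the compounds shown here alone, how a hydroxyl, an amine or a longer chain such as ethoxy would read at this position also remains open.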